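The source may hold more compounds than are shown below. What is called first, only, known or untested is meant among the compounds shown, and "the series" means these compounds.

Measured in an in vitro assay on HEK-tsA201 cells for antagonist activity at Neuronal acetylcholine receptor; alpha3/beta4 (Homo sapiens), read by fluorescence and calcium flux; on this read-out higher numbers stand for weaker inhibition and lower numbers for stronger inhibition:

Compound 1 `C=CCOc1ccc(C(=O)Nc2cccc(C)n2)cc1`: 31700 nM
Compound 2 `C#CCOc1ccc(C(=O)Nc2cccc(C)n2)cc1`: 21700 nM
Compound 3 `CCCNc1cccc(NC(=O)c2ccc(OCCC)cc2)n1`: 12600 nM

Compound 3 holds the lowest of the three numbers, though compound 2 lies within the scatter of it; only compound 1 stands beyond the scatter. Compound 4 `CCCOc1ccc(C(=O)Nc2cccc(NCc3ccccc3)n2)cc1` differs from compound 3 by phenyl in place of ethyl on a saturated chain carbon bound to a nitrogen on an aromatic ring. Going by the values given here, the single measured step, a 1.5-fold lower number from compound 1 to compound 2 (0.16 log units; within the scatter), concerns a different place and a different kind of group, so no measured step bears on this change directly. Nothing in these numbers therefore points to a step beyond the scatter in this assay, in either direction. Compound 4 is estimated at 10000 nM, with a range from 3000 nM to 40000 nM, which corresponds to an expected step of a 1.3-fold lower number from compound 3 to compound 4 (0.10 log units; within the scatter).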

Compound 4, half-maximal inhibitory concentration: > 100000 nM
Compound 4 gave a limit, no number; the forecaster's own chance of this, stated with the estimate: 15%; at least 10-fold (1.00 log units) between middle value and limit.
By their numbers in this assay, from the lowest: compounds 3, 2 and 1 (each within the scatter of the next, the first and the last beyond it). At a limit, above all of these: compound 4.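

Swapping propylamino for benzylamino gives an at least 7.9-fold higher number from compound 3 to compound 4 (0.89 log units; beyond the scatter), the only step between compounds differing in one place that lies beyond the scatter, whereas the earlier step, a 1.5-fold lower number from compound 1 to compound 2 (0.16 log units; within the scatter), stayed within it. This position therefore responds to the change from ethyl to phenyl, with inhibition weakening. Compound 4 gives > 100000 nM, which is a limit and not a number, so the step's full size stays unknown because of that limit: the limit of > 100000 nM in this assay, at which 1 of the 4 values shown sits.

The compounds shown leave open whether this loss is particular to phenyl. A cyclohexyl ring, a longer chain or a terminal amine at this place could still read differently.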